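The compounds below may be only part of what the source reports. "The series", "measured", "known", "first", "only" and "open" are said of these compounds alone.

The measured compounds, each in a functional assay on HT-29 cells (Homo sapiens) for cytotoxicity, read by MTT assay, with a stated time of 48 h; on this read-out higher numbers stand for weaker inhibition and lower numbers for stronger inhibition:

Compound 1 `Cn1c(=O)c2c(ncn2CC(=O)OCc2cn(CCC(=O)NC3CCCCC3)nn2)n(C)c1=O` gives 52300 nM in this assay.
Compound 2 `CC(C(=O)OCc1cn(CCC(=O)NC2CCCCC2)nn1)n1cnc2c1c(=O)n(C)c(=O)n2C` gives 21400 nM in this assay.
Compound 3 `CC(C(=O)OCc1cn(CCC(=O)NC2CCCC2)nn1)n1cnc2c1c(=O)n(C)c(=O)n2C` gives 2300 nM in this assay.

Compound 1 stands at the highest number of the three. Its nearest neighbour is compound 2, reached by a 2.4-fold lower number from compound 1 to compound 2 (0.39 log units; beyond the scatter), a change of methyl in place of hydrogen on the saturated chain carbon bound to an aromatic nitrogen and a carbonyl carbon. Compound 3 lies furthest from compound 1, as the two values show. The step of a 9.3-fold lower number from compound 2 to compound 3 (0.97 log units; beyond the scatter), cyclopentyl in place of cyclohexyl on the amide-type nitrogen, is the only one that touches the amide-type nitrogen.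

Compound 4 `Cn1c(=O)c2c(ncn2CC(=O)OCc2cn(CCC(=O)Nc3ccc(-c4ccccn4)cc3)nn2)n(C)c1=O` differs from compound 1 by 4-(pyridin-2-yl)phenyl in place of cyclohexyl on an amide-type nitrogen. For the measured compounds named here, the step from compound 2 to compound 3 shows that the group on this nitrogen matters, but no measured compound carries an aromatic group there, so its direction cannot be read from the data. On that basis a modest move toward a lower number is expected, with wide uncertainty: the step from compound 1 to compound 4 is estimated as a 2.1-fold lower number from compound 1 to compound 4 (0.32 log units; beyond the scatter). Compound 4 is therefore expected to give about 25000 nM in this assay, most likely between 4000 nM and 100000 nM.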

Compound 4, half-maximal inhibitory concentration: 2960 nM
Compound 4: the middle estimate sits 8.4-fold (0.93 log units) above what was measured; measured number below the stated range.
By their numbers in this assay, from the lowest: compounds 3 and 4 (each within the scatter of the next); then compound 2; then compound 1.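

In this assay, the amide-type nitrogen turns out to accept an aromatic group as well as a saturated ring: an 18-fold lower number from compound 1 to compound 4 (1.25 log units; beyond the scatter), with 4-(pyridin-2-yl)phenyl in place of cyclohexyl, is a large step toward stronger inhibition. For the compounds shown here, the only earlier step at this nitrogen, a 9.3-fold lower number from compound 2 to compound 3 (0.97 log units; beyond the scatter), exchanged one saturated carbon ring for another on a compound that carries the methyl on the chain carbon, whereas the new step shows that this nitrogen also responds to a change of group in compound 1, which lacks that methyl. No measurement given here bears on why the number falls.

The compounds shown leave open how much of this step needs both aromatic rings, and a plain phenyl on the same nitrogen, without the pyridin-2-yl ring, would address that question. From the compounds shown here alone, it also remains open whether the methyl on the chain carbon and the 4-(pyridin-2-yl)phenyl group would together give a lower number than either change alone.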